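Swapping Bromo for Methoxy: From Compound 3 to Compound 4

The source may report more compounds than this note shows. Statements on the series, on what has been measured and on what is new or still open speak of the compounds shown alone.

Compound 1 `c1cncc(N2CCCNCCC2)c1` is the unsubstituted member of this small set. In a functional assay on HEK293 cells for agonist activity at Neuronal acetylcholine receptor; alpha4/beta2 (Homo sapiens), read by FLIPR and calcium flux (on this read-out higher numbers stand for an effect only at larger amounts of compound and lower numbers for an effect already at smaller amounts), compound 1 gives 36.3 nM. Compound 2 `Clc1cncc(N2CCCNCCC2)c1` carries a chloro on an aromatic carbon and in this assay compound 2 gives 170 nM; compound 3 `Brc1cncc(N2CCCNCCC2)c1` carries a bromo instead and in this assay compound 3 gives 182 nM. The steps are a 4.7-fold higher number from compound 1 to compound 2 (0.67 log units; beyond the scatter) and a 5.0-fold higher number from compound 1 to compound 3 (0.70 log units; beyond the scatter), while a 1.1-fold higher number from compound 2 to compound 3 (0.03 log units; within the scatter) shows the two halogens cannot be told apart here. Compound 3 thus stands at the high end of the three numbers, with compound 2 within the scatter of it and compound 1 well below.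

Compound 4 `COc1cncc(N2CCCNCCC2)c1` differs from compound 3 by methoxy in place of bromo on an aromatic carbon. Going by the values given here, no measured step involves a methoxy, so the bearing steps are indirect: both halogens raised the number from compound 1, and the halogen-to-halogen swap left it unchanged. The account therefore expects a modest fall with wide uncertainty, a 1.8-fold lower number from compound 3 to compound 4 (0.26 log units; within the scatter). For compound 4 the estimate in this assay is 100 nM, with a range from 30 nM to 400 nM.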

Compound 4, half-maximal effective concentration: 120 nM
The estimate for compound 4 lay 1.2-fold (0.08 log units) below the measured number; low and high end bracket the measured number.
By their numbers in this assay, from the lowest: compound 1; then compounds 4, 2 and 3 (each within the scatter of the next).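

In this assay, methoxy on this aromatic carbon, two atoms from the ring nitrogen, cannot be told apart from either halogen: a 1.5-fold lower number from compound 3 to compound 4 (0.18 log units; within the scatter) and a 1.4-fold lower number from compound 2 to compound 4 (0.15 log units; within the scatter) both stay within the scatter, even though methoxy brings a hydrogen-bond acceptor that bromo lacks. The closeness seen so far between chloro and bromo therefore extends to a group that is not a halogen, while a 3.3-fold higher number from compound 1 to compound 4 (0.52 log units; beyond the scatter) lies beyond the scatter and keeps compound 1, with hydrogen at this place, apart from all three substituted compounds. No measurement at hand bears on why these three groups fall together. Going by these compounds, it remains open whether an amine, a carboxylic acid or a longer chain such as ethoxy would join these three compounds or part from them, and whether any group here would match compound 1.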